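The compounds below may be only part of what the source reports. "The series", "measured", "known", "first", "only" and "open" are said of these compounds alone.

Within the data shown here, compound 3 `CCC(CO[C@H](CC=C(C)C)C1=CC(=O)c2c(O)ccc(O)c2C1=O)OC(C)=O` gives 25400 nM in a functional assay on DU-145 cells (Homo sapiens) for cytotoxicity, read by MTT assay (a lower number here means a stronger inhibitor, a higher number a weaker inhibitor), the second highest of the three numbers so far: compound 2 `CC(C)=CC[C@@H](OCC(C)O)C1=CC(=O)c2c(O)ccc(O)c2C1=O` sits nearest at 16100 nM, compound 1 `CCCC(CC(=O)O[C@H](CC=C(C)C)C1=CC(=O)c2c(O)ccc(O)c2C1=O)OC(C)=O` furthest at 55700 nM. Among the measured compounds shown here, the one recorded step on the same oxygen, a 1.6-fold higher number from compound 2 to compound 3 (0.20 log units; within the scatter), stayed within the scatter. Compound 4 `CCC(O)(CC)CC(=O)O[C@H](CC=C(C)C)C1=CC(=O)c2c(O)ccc(O)c2C1=O` carries (2-ethyl-2-hydroxybutyl)carbonyl in place of 2-acetoxybutyl on an oxygen on a saturated carbon. For the measured compounds named here, only the step from compound 2 to compound 3 bears directly on this change, and it was small; compound 1 and compound 3 share no recorded step, their values showing compound 1 higher. The change brings back a hydrogen-bond donor, as compound 2 has, so the expectation is a step of a 1.1-fold higher number from compound 3 to compound 4 (0.04 log units; within the scatter), within the scatter, and compound 4 is estimated at 28000 nM, range 11000 nM to 70000 nM.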

Compound 4, half-maximal inhibitory concentration: 67000 nM
For compound 4 the middle estimate is 2.4-fold (0.38 log units) below the measured one; measured number inside the range.
By their numbers in this assay, from the lowest: compounds 2 and 3 (each within the scatter of the next); then compounds 1 and 4 (each within the scatter of the next).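

In this assay the (2-ethyl-2-hydroxybutyl)carbonyl group on this oxygen gives a 2.6-fold higher number from compound 3 to compound 4 (0.42 log units; beyond the scatter), beyond the scatter, although it carries a hydrogen-bond donor. The donor alone therefore does not keep the number low: the comparison with the 2-hydroxypropyl group gives a 4.2-fold higher number from compound 2 to compound 4 (0.62 log units; beyond the scatter). On the saturated chain carbon bound to a carbonyl carbon, 1-ethyl-1-hydroxypropyl and 1-acetoxybutyl are not told apart, with a 1.2-fold higher number from compound 1 to compound 4 (0.08 log units; within the scatter).

Nothing available accounts for these steps. Still open, from the compounds shown here alone, is how an amine or a carboxylic acid on this chain would read.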